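Swapping a Hydroxycyclobutylmethyl Group for an Oxanyl Ring

The source may hold more compounds than are shown below. What is called first, only, known or untested is meant among the compounds shown, and "the series" means these compounds.

Of the compounds shown here, three sharing one core have been tested in an ADME assay on S9 fraction from liver (Rattus norvegicus) for metabolic stability, with a stated time of 1 h; a lower number here means that less of the compound is left, a higher number that more of the compound is left. Compound 1 `N#Cc1cnc(NCc2cnccc2C(F)(F)F)cc1N[C@H]1C[C@H](O)C1` gives 82%, compound 2 `N#Cc1cnc(NCc2cnccc2C(F)(F)F)cc1NC[C@H]1C[C@@H](O)C1` gives 44%, and compound 3 `N#Cc1cnc(NCc2cnccc2C(F)(F)F)cc1NC[C@H]1CC[C@@H](O)CC1` gives 18%. Compound 2 therefore stands second highest of the three, between the other two and beyond the scatter from each. The two steps that lead to it are large: a number 38 percentage points lower from compound 1 to compound 2 (beyond the scatter) and a number 26 percentage points lower from compound 2 to compound 3 (beyond the scatter).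

Compound 4 `N#Cc1cnc(NCc2cnccc2C(F)(F)F)cc1NC1CCOCC1` differs from compound 2 as follows: oxan-4-yl in place of (3-hydroxycyclobutyl)methyl on a nitrogen on an aromatic ring. The step from compound 1 to compound 2 bears most closely on this change, since it shows what happens when the ring is carried through a methyl link rather than placed on the nitrogen itself; compound 4 returns to the latter arrangement. The step from compound 2 to compound 3 shows that the ring itself also matters. A rise beyond the scatter is therefore expected, and compound 4 is estimated at 65%, within 42% to 85%, which would mean an expected step of a number 21 percentage points higher from compound 2 to compound 4 (beyond the scatter).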

Compound 4, percent of the compound remaining: 17%
The estimate for compound 4 lay 48 percentage points above the measured number, and the stated range ends above it.
By their numbers in this assay, from the lowest: compounds 4 and 3 (each within the scatter of the next); then compound 2; then compound 1.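

In this assay there is a number 27 percentage points lower from compound 2 to compound 4 (beyond the scatter) and also a number 65 percentage points lower from compound 1 to compound 4 (beyond the scatter) with oxan-4-yl, so attaching a ring directly to the nitrogen does not by itself give the high number seen for compound 1. There is also a number 1 percentage points lower from compound 3 to compound 4 (within the scatter) even though the two groups differ in both ring and link, so the compounds carrying oxan-4-yl and (4-hydroxycyclohexyl)methyl sit together at the low end of this short series. No measurement here explains why the change has this result.

The compounds shown leave open whether ring size or the ring oxygen matters more here. A 4-hydroxycyclohexyl group or an oxetan-3-yl ring placed directly on the nitrogen would help separate the two.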